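The source may hold more compounds than are shown below. What is called first, only, known or untested is meant among the compounds shown, and "the series" means these compounds.

In an assay on RBL-1 cells with Polyunsaturated fatty acid 5-lipoxygenase (Rattus norvegicus) as the target (on this read-out higher numbers stand for weaker inhibition and lower numbers for stronger inhibition), compound 3 `Cc1cc(Cc2ccccc2)c(O)c2ccccc12` gives 20 nM. In this assay compound 1 `Cc1ccc(Cc2ccc3ccccc3c2O)cc1` gives 24 nM. In this assay compound 2 `Oc1c(Cc2ccccn2)ccc2ccccc12` gives 390 nM.

Compound 3 carries the lowest of the three numbers, but compound 1 lies within the usual scatter of it, so the two cannot be told apart; only compound 2 stands clearly apart, beyond the scatter, with the weaker inhibition. Compound 4 `NS(=O)(=O)c1cc(Cc2ccccc2)c(O)c2ccccc12` differs from compound 3 by sulfamoyl in place of methyl on an aromatic carbon. Among the measured compounds shown here, no measured pair tests this kind of change, so any expectation rests on loose grounds. For the measured compounds named here, a weakening step is expected in this assay, probably beyond the scatter, because compound 2 gives 390 nM as the one compound that departs from a plain hydrocarbon substituent. This amounts to an expected 15-fold higher number from compound 3 to compound 4 (1.18 log units; beyond the scatter). For compound 4 the expected value is 300 nM, within a range from 50 nM to 2000 nM.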

Compound 4, half-maximal inhibitory concentration: 9400 nM
Compound 4: middle estimate off by 31-fold (1.50 log units), on the low side; the whole stated range lies below it.
By their numbers in this assay, from the lowest: compounds 3 and 1 (each within the scatter of the next); then compound 2; then compound 4.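

Sulfamoyl in place of methyl on the aromatic carbon para to the hydroxy group gives a 470-fold higher number from compound 3 to compound 4 (2.67 log units; beyond the scatter) in this assay, a large loss of inhibition. The earlier compounds never varied this carbon, so this is the only pair shown to reveal that inhibition here depends strongly on the group it carries. The change adds heavy atoms, a hydrogen-bond donor and hydrogen-bond acceptors all at once, and the pair cannot separate these differences.

From the compounds shown here alone, whether an amine or a carboxylic acid on this carbon would weaken inhibition as much remains open. No measurement shown gives a reason for the loss.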